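This account rests on a few compounds, and the source may have more. Where it says the series, first, only, none or still open, it means among the compounds named here.

Measured compounds: compound 1 `Cc1ccc(NC(=O)NC(=O)c2ccc(OCc3ccccc3F)cc2)cc1-c1nc2ccccc2[nH]1` gives 4110 nM; compound 2 `Cc1ccc(NC(=O)NC(=O)c2ccc(OCc3cccc(Cl)c3Cl)cc2)cc1-c1nc2ccccc2[nH]1` gives 42100 nM.

In a functional assay on SW-620 cells (Homo sapiens) for inhibition, read by MTT assay, with a stated time of 48 h (on this read-out lower numbers stand for stronger inhibition and higher numbers for weaker inhibition), compound 2 stands highest of the two numbers, with compound 1 the nearest, and the step of a 10-fold higher number from compound 1 to compound 2 (1.01 log units; beyond the scatter) shows how far they lie apart. Compound 3 `Cc1ccc(NC(=O)NC(=O)c2ccc(OCc3ccc(F)cc3)cc2)cc1-c1nc2ccccc2[nH]1` carries 4-fluorophenyl in place of 2,3-dichlorophenyl on a saturated chain carbon bound to an oxygen on an aromatic ring. Going by the values given here, that one measured step is the only guide: it ran the other way, large, beyond the scatter, when 2,3-dichlorophenyl entered. Reversing it, with fluorophenyl entering again, the number for compound 3 is expected to fall by about an 8.4-fold lower number from compound 2 to compound 3 (0.93 log units; beyond the scatter). Compound 3 is thus estimated at 5000 nM, between 1500 nM and 20000 nM.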

Compound 3, half-maximal inhibitory concentration: 35100 nM
Estimate against measurement, compound 3: 7.0-fold (0.85 log units) below; measured number outside the range, above it.
By their numbers in this assay, from the lowest: compound 1; then compounds 3 and 2 (each within the scatter of the next).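

In this assay, 4-fluorophenyl in place of 2,3-dichlorophenyl gives a 1.2-fold lower number from compound 2 to compound 3 (0.08 log units; within the scatter), so this change separates compound 2 and compound 3 by no more than repeat measurements would. Fluorine alone therefore does not secure the lower number: 4-fluorophenyl in place of 2-fluorophenyl gives an 8.5-fold higher number from compound 1 to compound 3 (0.93 log units; beyond the scatter), leaving compound 1 apart from the other two. Nothing measured here explains why these groups differ.

From the compounds shown here alone, it remains open whether an unsubstituted benzyl would stand with compound 1 or with the other two. Going by these compounds, the effect of a benzyl carrying an amine or a carboxylic acid also remains open.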